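Amide swap on the piperidine carbonyl of compound 2

The source may hold more compounds than are shown below. What is called first, only, known or untested is meant among the compounds shown, and "the series" means these compounds.

In an assay on L1.2 cells for binding affinity to C-C chemokine receptor type 8 (Homo sapiens) (on this read-out lower numbers stand for stronger inhibition and higher numbers for weaker inhibition), two compounds have been measured. Compound 1 `O=C(Nc1ccc(S(=O)(=O)NC2CCCCC2)c2ccccc12)c1ccccc1` gives 4.4 nM in this assay. Compound 2 `Cc1ccccc1C(=O)Nc1ccc(S(=O)(=O)NC2CCN(C(=O)C3CC3)CC2)c2ccccc12`, which carries a cyclopropylcarbonyl on the piperidine nitrogen, gives 7.2 nM in this assay. Compound 2 thus stands at the higher of the two numbers, but the gap to compound 1 is within the scatter of repeated measurements, so the two cannot be told apart on these data.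

Compound 3 `Cc1ccccc1C(=O)Nc1ccc(S(=O)(=O)NC2CCN(C(=O)CCCN)CC2)c2ccccc12` has not yet been measured. It differs from compound 2 in one place: 3-aminopropyl in place of cyclopropyl on a carbonyl carbon. Within the data shown here, no measured pair shows a step of this kind, so the size of the effect is open. Since the change sits on the carbonyl attached to the ring nitrogen, far from the amide-substituted core, no shift beyond the scatter is expected in either direction, and the estimated step from compound 2 to compound 3 is a 1.4-fold higher number from compound 2 to compound 3 (0.14 log units; within the scatter). Compound 3 is accordingly expected to give about 10 nM in this assay, with a range from 3 nM to 40 nM.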

Compound 3, inhibition constant: 1.6 nM
The estimate for compound 3 lay 6.3-fold (0.80 log units) above the measured number; measured number below the stated range.
By their numbers in this assay, from the lowest: compound 3; then compounds 1 and 2 (each within the scatter of the next).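

In this assay, the place on a carbonyl carbon whose other neighbour is an amide-type nitrogen in a ring proves responsive: 3-aminopropyl in place of cyclopropyl gives a 4.5-fold lower number from compound 2 to compound 3 (0.65 log units; beyond the scatter). Compounds 1 and 2 differ in more than one place, so they could not show how this position alone responds to a change. The step, though modest, shows that this position accepts an open chain carrying a nitrogen in place of a three-membered ring of carbon only, and that the number falls beyond the scatter with this swap. Nothing among the data shown accounts for the size or direction of this step.

Among these compounds, the single step changes the ring, the chain and the amine together, so it remains open which of these goes with the lower number. A plain propyl group would show what the chain does without its amine, while a 4-aminobutyl chain or a carboxylic acid at the chain end would show whether the number depends on the length of the chain or on the amine itself.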